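Methoxyphenyl for fluoromethylphenyl on the chain carbon

The source may hold more compounds than are shown below. What is called first, only, known or untested is meant among the compounds shown, and "the series" means these compounds.

Of the compounds shown here, three have numbers so far. Compound 1 `Cc1ccc(CS/C(=C/c2ccc(F)c(C)c2)C(=O)c2ccc(Cl)cc2)cc1` gives 25000 nM in a functional assay on DU-145 cells (Homo sapiens) for inhibition, read by trypan blue exclusion, with a stated time of 96 h (a higher number here means a weaker inhibitor of growth, a lower number a stronger inhibitor of growth), the highest of the three numbers. Compound 2 `COc1cc(OC)c(/C=C(/SCc2ccc(Cl)cc2)C(=O)c2ccc(Br)cc2)c(OC)c1` gives 1000 nM in this assay, a lower number beyond the scatter and the furthest from compound 1. Compound 3 `COc1ccc(C(=O)/C(=C\c2ccc(O)c([N+](=O)[O-])c2)SCc2ccc(Br)cc2)cc1` gives 10000 nM in this assay, the nearest to compound 1 yet still beyond the scatter. No two of these compounds differ in one place only, so no single-point step is available among them.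

Compound 4 `COc1ccccc1/C=C(/SCc1ccc(C)cc1)C(=O)c1ccc(Cl)cc1` is not yet measured. It differs from compound 1 by 2-methoxyphenyl in place of 4-fluoro-3-methylphenyl on a double-bonded chain carbon bound to a double-bonded chain carbon. An oxygen-bearing aryl on that chain carbon is shared with compound 2, whose number 1000 nM is the lowest here, but compound 2 carries three methoxy groups and a different halogen on the ketone aryl, so the comparison is loose. A moderate step to a lower number, beyond the scatter, is expected for compound 4 in this assay. The estimate for compound 4 is 10000 nM, within 3000 nM to 30000 nM. The expected step is a 2.5-fold lower number from compound 1 to compound 4 (0.40 log units; beyond the scatter).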

Compound 4, concentration for 50% growth inhibition: 10000 nM
The estimate for compound 4 equals the measured number at the digits printed; the measured number falls inside the stated range.
By their numbers in this assay, from the lowest: compound 2; then compounds 3 and 4 (each within the scatter of the next); then compound 1.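

Among these compounds, this is the first step that can be read at a single position: in this assay, 2-methoxyphenyl in place of 4-fluoro-3-methylphenyl gives a 2.5-fold lower number from compound 1 to compound 4 (0.40 log units; beyond the scatter), a modest step. The number at this chain carbon therefore responds to a change of aryl substituents with the rest of the structure held constant, and the entering group counts one hydrogen-bond acceptor where the leaving group counts none. No available measurement bears on the cause of this step.

With a single pair, the contribution of the entering methoxy group cannot be separated from that of the departing fluorine and methyl groups. Going by these compounds, what an unsubstituted phenyl or an aminophenyl on the same chain carbon would give remains open.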